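Removing the Chloro Group: Compound 3 to Compound 4

The compounds below may be only part of what the source reports. "The series", "measured", "known", "first", "only" and "open" are said of these compounds alone.

Compound 1, `COc1ccc(/C=C2\N=C(c3ccc(C)cc3)N(C(=O)c3nc4c(c(C)nn4-c4ccccc4)c(=O)[nH]3)NC2=O)cc1`: in an ADME assay on WI-38 cells (Homo sapiens) for cytotoxicity, read by MTT assay, with a stated time of 48 h (on this read-out higher numbers stand for weaker inhibition and lower numbers for stronger inhibition), compound 1 gives 36.8 nM.
Compound 2, `Cc1nn(-c2ccccc2)c2nc(C(=O)N3NC(=O)/C(=C/c4ccc(Cl)cc4)N=C3c3ccccc3)[nH]c(=O)c12`: in this assay compound 2 gives 31.8 nM.
Compound 3, `COc1ccc(/C=C2\N=C(c3ccc(Cl)cc3)N(C(=O)c3nc4c(c(C)nn4-c4ccccc4)c(=O)[nH]3)NC2=O)cc1`: in this assay compound 3 gives 25 nM.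

Compound 3 has the lowest of the three numbers shown, but its gaps to compound 2 and to compound 1 both lie within the usual scatter of repeated measurements, so no order among the three can be read from these values. Compound 4, `COc1ccc(/C=C2\N=C(c3ccccc3)N(C(=O)c3nc4c(c(C)nn4-c4ccccc4)c(=O)[nH]3)NC2=O)cc1`, differs from compound 3 in one place: hydrogen in place of chloro on an aromatic carbon. Within the data shown here, the only measured step that touches this part of the structure is a 1.5-fold lower number from compound 1 to compound 3 (0.17 log units; within the scatter), which exchanged one small group for another on an aromatic carbon and moved the number by less than the scatter. Among the measured compounds shown here, no measured pair removes the chloro group outright, and compound 2 carries its chloro group elsewhere, so it offers no direct comparison. The expectation therefore rests on that single small step, and the change from chloro to hydrogen is expected to shift the read-out little, with no direction beyond the scatter. Compound 4 is expected to give 32 nM in this assay, between 14 nM and 70 nM. This corresponds to an expected step of a 1.3-fold higher number from compound 3 to compound 4 (0.11 log units; within the scatter).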

Compound 4, half-maximal inhibitory concentration: 97.7 nM
The estimate for compound 4 lay 3.1-fold (0.48 log units) below the measured number; the whole stated range lies below it.
By their numbers in this assay, from the lowest: compounds 3, 2 and 1 (each within the scatter of the next); then compound 4.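

In this assay this position turns out not to be indifferent: with the methoxy group kept on the other aromatic ring, going from 4-chlorophenyl to phenyl gives a 3.9-fold higher number from compound 3 to compound 4 (0.59 log units; beyond the scatter) and hydrogen in place of methyl gives a 2.7-fold higher number from compound 1 to compound 4 (0.42 log units; beyond the scatter) beyond the scatter, whereas exchanging methyl for chloro gave only a 1.5-fold lower number from compound 1 to compound 3 (0.17 log units; within the scatter) within it. Among these compounds, then, what separates the numbers is whether this ring carries a small group at all, not which of the two small groups it carries. Compound 2 goes against reading this as a simple rule about the plain phenyl, since it has that same ring and still gives a 3.1-fold higher number from compound 2 to compound 4 (0.49 log units; beyond the scatter) when methoxy takes the place of its chloro, so the number for a plain phenyl depends on what the rest of the molecule carries.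

The compounds shown leave open whether a fluoro, a hydroxyl, an amine or a longer chain at this position would behave like chloro and methyl or like hydrogen. Nothing measured here explains the rise on losing the group.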